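A few compounds are considered here, and "the series" means these few. Any claim that something is new, unique, unknown or untested is made for them only; others in the source may bear on it.

Measured so far: compound 1 `CC(=O)OCCO[C@H](CC=C(C)C)C1=CC(=O)c2c(O)ccc(O)c2C1=O`, compound 2 `CC[C@@](C)(O)CC(=O)O[C@H](CC=C(C)C)C1=CC(=O)c2c(O)ccc(O)c2C1=O`, compound 3 `COC(C)CO[C@H](CC=C(C)C)C1=CC(=O)c2c(O)ccc(O)c2C1=O`.

In a functional assay on DU-145 cells (Homo sapiens) for cytotoxicity, read by MTT assay (on this read-out higher numbers stand for weaker inhibition and lower numbers for stronger inhibition), compound 1 gives 15500 nM, compound 2 gives 12700 nM and compound 3 gives 16600 nM. The three numbers sit close together: a 1.2-fold lower number from compound 1 to compound 2 (0.09 log units; within the scatter), a 1.1-fold higher number from compound 1 to compound 3 (0.03 log units; within the scatter) and a 1.3-fold higher number from compound 2 to compound 3 (0.12 log units; within the scatter). Compound 2 carries the smallest number of the three, but none of its separations from the others is beyond the scatter.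

Compound 4 `CCCC(CC(=O)O[C@H](CC=C(C)C)C1=CC(=O)c2c(O)ccc(O)c2C1=O)OC(C)=O` differs from compound 2 by 1-acetoxybutyl in place of 1-hydroxy-1-methylpropyl on a saturated chain carbon bound to a carbonyl carbon. The nearest measured precedent is the step from an acetoxy group to a hydroxylated acyl group, a 1.2-fold lower number from compound 1 to compound 2 (0.09 log units; within the scatter), which lay within the scatter. Changes at this position have so far moved this assay little, so no step beyond the scatter is expected for compound 4. Compound 4 is therefore expected to give about 14000 nM (range 7000 nM to 28000 nM), an expected step of a 1.1-fold higher number from compound 2 to compound 4 (0.04 log units; within the scatter).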

Compound 4, half-maximal inhibitory concentration: 55700 nM
The estimate for compound 4 lay 4.0-fold (0.60 log units) below the measured number; measured number outside the range, above it.
By their numbers in this assay, from the lowest: compounds 2, 1 and 3 (each within the scatter of the next); then compound 4.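

Placing 1-acetoxybutyl in place of 1-hydroxy-1-methylpropyl on a saturated chain carbon bound to a carbonyl carbon gives, in this assay, a 4.4-fold higher number from compound 2 to compound 4 (0.64 log units; beyond the scatter), the first step beyond the scatter in this set. This position therefore does respond to change, which compounds 1, 2 and 3, all within the scatter of one another, did not show. The change replaces the whole group at once, so the step cannot be assigned to any single part of it.

On these data alone, whether 1-hydroxybutyl here would read like compound 2 or like compound 4 stays open, as does the outcome with an amine at this place. No measurement shown offers an explanation for the step.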